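Dimethoxy to trimethoxy aniline on the shared core

The source may hold more compounds than are shown below. What is called first, only, known or untested is meant among the compounds shown, and "the series" means these compounds.

The series keeps one core and varies the aryl group on the amine nitrogen. Compound 1 `O=[N+]([O-])c1ccc(Nc2nc(SCc3ccc(C(F)(F)F)cc3)nc3ccccc23)cc1` carries 4-nitrophenyl, and in a functional assay on MCF7 cells (Homo sapiens) for cytotoxicity, read by MTT assay, with a stated time of 72 h (a lower number here means a stronger inhibitor, a higher number a weaker inhibitor), compound 1 gives 17900 nM. Compound 2 `COc1cc(Nc2nc(SCc3ccc(C(F)(F)F)cc3)nc3ccccc23)cc(OC)c1` carries 3,5-dimethoxyphenyl, and in this assay compound 2 gives 6990 nM, a step of a 2.6-fold lower number from compound 1 to compound 2 (0.41 log units; beyond the scatter). Compound 3 `COc1ccc(Nc2nc(SCc3ccc(C(F)(F)F)cc3)nc3ccccc23)cc1OC` carries 3,4-dimethoxyphenyl. In this assay compound 3 gives only a limit, > 50000 nM, so its place among the numbers is not fixed (the limit of > 50000 nM in this assay, at which 1 of the 3 values shown sits). The steps into it are an at least 2.7-fold higher number from compound 1 to compound 3 (0.44 log units; beyond the scatter) and an at least 7.1-fold higher number from compound 2 to compound 3 (0.85 log units; beyond the scatter), both toward higher numbers.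

Compound 4 `COc1cc(Nc2nc(SCc3ccc(C(F)(F)F)cc3)nc3ccccc23)cc(OC)c1OC` follows: methoxy in place of hydrogen on an aromatic carbon. Compound 4 therefore holds the 3,5-dimethoxyphenyl pattern of compound 2 together with the 3,4-dimethoxyphenyl pattern of compound 3. The two bearing steps point opposite ways, a 2.6-fold lower number from compound 1 to compound 2 (0.41 log units; beyond the scatter) favouring the new arrangement and an at least 7.1-fold higher number from compound 2 to compound 3 (0.85 log units; beyond the scatter) counting against it, and the limit on compound 3 leaves the starting point open. The expected step is an at least 1.6-fold lower number from compound 3 to compound 4 (0.22 log units; that floor lies within the scatter), with wide uncertainty. Compound 4 is estimated at 30000 nM, between 8000 nM and 100000 nM, and another limit is possible.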

Compound 4, half-maximal inhibitory concentration: > 50000 nM
Compound 4: only a limit was reported; the forecaster's own chance of this, stated with the estimate: 40%; at least 1.6-fold (0.22 log units) between middle value and limit.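

Placed on compound 2, ortho to a methoxy group, the new methoxy gives an at least 7.1-fold higher number from compound 2 to compound 4 (0.85 log units; beyond the scatter) in this assay, so the 3,5-dimethoxyphenyl pattern does not keep its number once this carbon is substituted. Compound 3 and compound 4 share the 3,4-dimethoxyphenyl pattern, and each gives a limit rather than a number: the limit of > 50000 nM in this assay, at which 2 of the 4 values shown sit. On these data alone, the step from compound 3 to compound 4 cannot be read, and whether the third methoxy changes anything on that pattern stays unknown.

As far as these compounds go, whether a hydroxyl, a fluorine or an amine on this same carbon, in place of methoxy, would give a number in this assay stays open. Also open, from the compounds shown here alone, is whether a single methoxy on this carbon, without the other two methoxy groups, would end at a limit.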